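Swapping the sulfonamide for a sulfonate ester

A few compounds are considered here, and "the series" means these few. Any claim that something is new, unique, unknown or untested is made for them only; others in the source may bear on it.

Of the compounds shown here, two from this series have been measured in a functional assay on the whole organism (aorta) with Rattus norvegicus as the target; on this read-out higher numbers stand for larger maximal responses and lower numbers for smaller maximal responses. Compound 1, `COc1ccc(NS(=O)(=O)c2ccc3c(c2)C(n2ccccc2=O)=CC(C)(C)O3)cc1`, gives 77.9%. Compound 2, `CC1(C)C=C(n2ccccc2=O)c2cc(S(=O)(=O)Nc3ccc([N+](=O)[O-])cc3)ccc2O1`, gives 82.2%. Within the data shown here, the only step measured so far, a number 4.3 percentage points higher from compound 1 to compound 2 (within the scatter), changes a substituent on the remote aromatic ring and leaves the two values within the scatter of each other, so compound 2 cannot be separated from compound 1 on this read-out.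

Compound 3, `CC1(C)C=C(n2ccccc2=O)c2cc(S(=O)(=O)Oc3ccccc3)ccc2O1`, differs from compound 2 in one place: phenoxy in place of (4-nitrophenyl)amino on a sulfonyl sulfur. Among the measured compounds shown here, the measured step from compound 1 to compound 2 does not touch this position; it alters the remote ring while the sulfonamide linkage stays intact, so no measured step bears directly on the move from a (4-nitrophenyl)amino to a phenoxy on the sulfonyl sulfur. With the hydrogen-bond donor gone and the group shortened, the direction of any effect is undetermined from these data.

Compound 3 is therefore expected to give 70% in this assay, within the range 40% to 95%. The estimate implies a step of a number 12.2 percentage points lower from compound 2 to compound 3 (beyond the scatter), with wide uncertainty.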

Compound 3, largest response reached (Emax), in percent of the reference or control that the assay uses: 67.9%
For compound 3 the middle estimate is 2.1 percentage points above the measured one; the range from low to high includes it.
By their numbers in this assay, from the lowest: compounds 3, 1 and 2 (each within the scatter of the next, the first and the last beyond it).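

In this assay, among these compounds, the sulfonyl sulfur is the first position where a change gives a step beyond the scatter: phenoxy in place of (4-nitrophenyl)amino gives a number 14.3 percentage points lower from compound 2 to compound 3 (beyond the scatter), a modest step, and compound 3 still gives 67.9%, so the sulfonate ester keeps a sizeable maximal response. The reading depends on the sulfonamide used for comparison, since phenoxy in place of (4-methoxyphenyl)amino gives a number 10 percentage points lower from compound 1 to compound 3 (within the scatter), which stays within the scatter, and the sulfonate ester therefore separates from only one of the two sulfonamides. Nothing measured here bears on why this change acts as it does.

The change to compound 3 replaces the nitrogen linkage and removes the ring substituent in a single move, so the compounds shown leave open which of the two carries the step, a question that a plain phenylamino group on the sulfonyl sulfur would help to settle. They also leave open how the position would read with no aromatic ring on the linkage at all, as with a simple amine or an ethoxy group on the sulfonyl sulfur.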